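The compounds below may be only part of what the source reports. "The series", "measured", "known", "first", "only" and "open" are said of these compounds alone.

Measured compounds:
compound 1 `COCCCNS(=O)(=O)CCn1c([N+](=O)[O-])cnc1C` gives 17000000 nM in a physicochemical assay for solubility, read by HPLC; on this read-out higher numbers stand for higher solubility and lower numbers for lower solubility;
compound 2 `Cc1ncc([N+](=O)[O-])n1CCS(=O)(=O)NCCO` gives > 49300000 nM in this assay, which is a limit of the assay and not a number;
compound 3 `CCN(CC)CCNS(=O)(=O)CCn1c([N+](=O)[O-])cnc1C` gives 45700000 nM in this assay.

Compound 2 therefore sits at the upper edge of the numbers shown, described by the limit of > 49300000 nM in this assay, at which 1 of the 3 values shown sits, with only a limit known for it. The step to compound 4 `Cc1ncc([N+](=O)[O-])n1CCS(=O)(=O)N1CCOCC1` is morpholin-4-yl in place of (2-hydroxyethyl)amino on a sulfonyl sulfur. Within the data shown here, no measured step changes what sits on the sulfonyl sulfur; the measured steps vary the chain two bonds along from the sulfonamide nitrogen instead. Those steps were an at least 2.9-fold higher number from compound 1 to compound 2 (0.46 log units; beyond the scatter), a 2.7-fold higher number from compound 1 to compound 3 (0.43 log units; beyond the scatter) and an at least 1.0-fold lower number from compound 2 to compound 3 (0.03 log units; that floor lies within the scatter), so the whole set spans a modest range in this assay and the two compounds without a methoxymethyl group both stand high. Among the measured compounds shown here, since no measured step removes the sulfonamide hydrogen, the present change is outside what the data cover. Compound 4 is expected to give 15000000 nM in this assay, within 4000000 nM to 49300000 nM, a change of an at least 3.2-fold lower number from compound 2 to compound 4 (0.51 log units; beyond the scatter) that is only an estimate.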

Compound 4, solubility: 2770000 nM
Beside the measured number, compound 4's estimate is 5.4-fold (0.73 log units) above it; the whole stated range lies above it.
By their numbers in this assay, from the lowest: compound 4; then compound 1; then compound 3. At a limit, above all of these: compound 2.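

Among these compounds, for the first time, a step changes what sits on the sulfonyl sulfur, and in this assay morpholin-4-yl in place of (2-hydroxyethyl)amino gives an at least 17-fold lower number from compound 2 to compound 4 (1.25 log units; beyond the scatter). Compound 2 is held only by a limit of the assay, not a number, so that step is a floor: the limit of > 49300000 nM in this assay, at which 1 of the 4 values shown sits. Morpholin-4-yl in place of (3-methoxypropyl)amino points the same way, with a 6.1-fold lower number from compound 1 to compound 4 (0.79 log units; beyond the scatter), so both steps at this position, each of which takes out the sulfonamide hydrogen and closes a six-membered ring, go downward.

The compounds shown do not separate the loss of that hydrogen from the presence of the ring. A dimethylamino group on the sulfonyl sulfur, which has no ring, or a piperazin-1-yl ring in the same place, would be the comparison that could tell these apart.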